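The source may report more compounds than this note shows. Statements on the series, on what has been measured and on what is new or still open speak of the compounds shown alone.

Four compounds share an amide of benzoic acid joined through a short unsaturated chain to a pyrimidinone core. Compound 1 `O=C(NC/C=C\Cn1ccc(=O)[nH]c1=O)c1ccccc1` and compound 3 `O=C(NC/C=C\Cn1ccc(=O)[nH]c1=O)c1ccc(F)cc1` carry one core, while compound 2 `Nc1ccn(C/C=C\CNC(=O)c2ccccc2)c(=O)n1` and compound 4 `Nc1ccn(C/C=C\CNC(=O)c2ccc(F)cc2)c(=O)n1` carry another; the difference between the two cores is not broken down here. Compound 3 is compound 1 with fluoro in place of hydrogen on an aromatic carbon, and compound 4 is compound 2 with the same change, (fluoro in place of hydrogen on an aromatic carbon); the surroundings of the place are described in identical words for both pairs, so this is the same change made on two cores.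

All four belong to a functional assay on MIA PaCa-2 cells (Homo sapiens) for cytotoxicity, read by MTT assay, with a stated time of 72 h; on this read-out higher numbers stand for weaker inhibition and lower numbers for stronger inhibition. Compound 1 gives > 100000 nM, which is a limit of the assay and not a number. Compound 2 likewise gives only a limit, > 100000 nM. Compound 3 also gives a limit, > 100000 nM. The step that the two limits leave unreadable from compound 1 to compound 3 cannot be sized, due to the limit of > 100000 nM in this assay, at which 3 of the 3 values shown sit.

Compound 4 has not yet been tested. The expectation for it rests on compound 3, whose result stayed at the limit > 100000 nM after the same change was made on the other core. The expected step is therefore a step that the limit leaves unreadable from compound 2 to compound 4. For compound 4 the estimate is 150000 nM, most likely reported again only as a limit, within a range from 50000 nM to 500000 nM.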

Compound 4, half-maximal inhibitory concentration: > 100000 nM
Compound 4 ended at the assay's limit (the forecaster's own chance of this, stated with the estimate: 85%); the middle value does not contradict the limit.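

Compound 2 and compound 4 both end at a limit of the assay rather than at a number, so the step between them, phenyl to 4-fluorophenyl, cannot be sized, due to one thing: the limit of > 100000 nM in this assay, at which 4 of the 4 values shown sit. The compounds shown leave open how strongly any of the four acts in this assay, and whether fluoro in place of hydrogen makes any difference on either core.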